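Sulfonamide series: compound 4 after compound 2

The compounds below may be only part of what the source reports. "The series", "measured", "known", "first", "only" and "open" are said of these compounds alone.

For the measured compounds named here, the three measured members have been tested in a functional assay on A549 cells (Homo sapiens) for cytotoxicity, read by sulforhodamine B assay, with a stated time of 72 h; on this read-out higher numbers stand for weaker inhibition and lower numbers for stronger inhibition. Compound 1 `Cc1cc(C)nc(NS(=O)(=O)c2ccc(NCc3coc4ccccc4c3=O)cc2)n1` gives 55800 nM in this assay. Compound 2 `Cc1cc(NS(=O)(=O)c2ccc(NC3=NC(=O)/C(=C\c4coc5ccccc5c4=O)S3)cc2)no1` reaches only the limit of the assay, > 100000 nM, and no number. Compound 3 `Cc1cc(NS(=O)(=O)c2ccc(N3C(=O)/C(=C/c4coc5ccccc5c4=O)N=C3c3ccc(Cl)cc3)cc2)no1` likewise reaches only the limit of the assay, > 100000 nM. Compound 2 therefore stands at the limit rather than at a measured value, and the limit of > 100000 nM in this assay, at which 2 of the 3 values shown sit, frames two of the three results shown; only compound 1 carries a number in this assay.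

Going by the values given here, no pair of measured compounds differs in a single place, so nothing measured tells how a change at the sulfonamide nitrogen moves the read-out. Compound 4 `NS(=O)(=O)c1ccc(NC2=NC(=O)/C(=C\c3coc4ccccc4c3=O)S2)cc1` differs from compound 2 by hydrogen in place of 5-methyl-1,2-oxazol-3-yl on a sulfonamide nitrogen; the rest of the shared core is kept. Since compound 2 gives only a limit, a step in either direction beyond the scatter cannot be excluded, but the expectation for compound 4 is a value of the same order, and the step of a number no higher from compound 2 to compound 4 (the limit leaves the size open) is expected to be small. Compound 4 is estimated at 100000 nM, within 30000 nM to 300000 nM, with a fair chance that this assay again reports only a limit.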

Compound 4, half-maximal inhibitory concentration: 2230 nM
For compound 4 the middle estimate is 45-fold (1.65 log units) above the measured one; the whole stated range lies above it.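

In this assay, for the compounds shown here, hydrogen in place of 5-methyl-1,2-oxazol-3-yl on the sulfonamide nitrogen gives an at least 44-fold lower number from compound 2 to compound 4 (1.65 log units; beyond the scatter), the first comparison that differs in one place. The substituent on this nitrogen is therefore not indifferent to the read-out: with the rest of the shared core kept, the change alone yields a measured number, with compound 4 at 2230 nM. The true size of the step stays unknown, as the value for compound 2 is only a limit of the assay: the limit of > 100000 nM in this assay, at which 2 of the 4 values shown sit.

This single step cannot show whether the lower number comes from the hydrogen itself or simply from the loss of the 5-methyl-1,2-oxazol-3-yl group, and a methyl or acetyl group on the same sulfonamide nitrogen would help to separate these two readings. From the compounds shown here alone, it also remains open whether the same change would act in the same way on the core of compound 3, which carries the same 5-methyl-1,2-oxazol-3-yl group on its sulfonamide nitrogen.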